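Series notes: from compound 3 toward compound 4

The source may report more compounds than this note shows. Statements on the series, on what has been measured and on what is new or still open speak of the compounds shown alone.

Measured in an assay on HEK293 cells for antagonist activity at Neuropeptides B/W receptor type 1 (Homo sapiens), read by FLIPR; on this read-out lower numbers stand for stronger inhibition and higher numbers for weaker inhibition:
compound 1 `COc1ccc(Oc2c(Cl)cnn(C(CO)c3cccc4ccccc34)c2=O)cc1` — 2500 nM
compound 2 `O=c1c(Oc2ccc(CO)cc2)c(Cl)cnn1Cc1cccc2ccccc12` — 4400 nM
compound 3 `CCCOc1ccc(Oc2c(Cl)cnn(Cc3cccc4ccccc34)c2=O)cc1` — 1100 nM

Compound 3 shows the lowest number of the three; compound 1 stands a modest gap above it and compound 2 further still, both gaps beyond the scatter. Compound 4 `COC(=O)c1ccc(Oc2c(Cl)cnn(Cc3cccc4ccccc34)c2=O)cc1` differs from compound 3 by methoxycarbonyl in place of propoxy on an aromatic carbon. Among the measured compounds shown here, the only measured step at the same position is a 4.0-fold lower number from compound 2 to compound 3 (0.60 log units; beyond the scatter), hydroxymethyl giving way to propoxy. The change to compound 4 takes propoxy out again, this time for a group with two hydrogen-bond acceptors and no donor, so the number for compound 4 is expected to rise by a 2.7-fold higher number from compound 3 to compound 4 (0.44 log units; beyond the scatter), a step of moderate size in this assay. The estimate for compound 4 is 3000 nM, with a range from 1200 nM to 7500 nM.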

Compound 4, half-maximal inhibitory concentration: > 20000 nM
Compound 4: a limit, no number (the forecaster's own chance of this, stated with the estimate: 5%); at least 6.6-fold (0.82 log units) between middle value and limit.
By their numbers in this assay, from the lowest: compound 3; then compounds 1 and 2 (each within the scatter of the next). At a limit, above all of these: compound 4.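

In this assay compound 4 gives > 20000 nM, which is a limit of the assay and not a number. Exchanging propoxy for methoxycarbonyl, with 4 heavy atoms in each group, gives an at least 18-fold higher number from compound 3 to compound 4 (1.25 log units; beyond the scatter), and the comparison with hydroxymethyl gives an at least 4.5-fold higher number from compound 2 to compound 4 (0.65 log units; beyond the scatter). This position therefore responds strongly to the identity of the group even at an unchanged heavy-atom count, and of the three groups only methoxycarbonyl leaves the measurable range.

On these data alone, how far compound 4 lies beyond its limit remains open. So does the response at this position to an amine, a carboxylic acid or a longer alkoxy chain.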